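The source may hold more compounds than are shown below. What is called first, only, known or untested is meant among the compounds shown, and "the series" means these compounds.

Compound 1 `CN(C[C@@H]1Cc2c(cccc2N2CCNCC2)CN1)[C@H]1CCCc2cccnc21`: 313 nM
Compound 2 `CN(C[C@H]1Cc2c(cccc2N2CCN3CCC[C@H]3C2)CN1)[C@H]1CCCc2cccnc21`: 2.92 nM
Compound 3 `CC(C)N(C[C@H]1Cc2c(cccc2N2CCNCC2)CN1)[C@H]1CCCc2cccnc21`: 364 nM

In a functional assay on CCRF-CEM cells for antagonist activity at C-X-C chemokine receptor type 4 (Homo sapiens), read by calcium flux, with stated times of 25 min and 90 s (on this read-out higher numbers stand for weaker inhibition and lower numbers for stronger inhibition), compound 2 gives the lowest number of the three, at 2.92 nM. Compound 1 gives 313 nM and compound 3 gives 364 nM; both of those gaps to compound 2 lie well beyond the usual scatter, so compound 2 is the strongest inhibitor among the measured set.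

Compound 4 `CCN1CCN(c2cccc3c2C[C@H](CN(C)[C@H]2CCCc4cccnc42)NC3)CC1` has not yet been measured. It differs from compound 2 in one place: a group of 8 heavy atoms (6 carbon, 2 nitrogen; one six-membered non-aromatic ring with 2 hetero atoms) in place of a group of 9 heavy atoms (7 carbon, 2 nitrogen; one five-membered non-aromatic ring with 1 hetero atom, one six-membered non-aromatic ring with 2 hetero atoms), on an aromatic carbon. The fused two-ring amine of compound 2 is thus opened to a single ring carrying an ethyl chain on its distal nitrogen, while the rest of the shared core is unchanged.

Among the measured compounds shown here, since no measured pair tracks this exact change, the expectation rests on the two ends already seen: compound 1 with the bare ring at 313 nM and compound 2 with the fused system at 2.92 nM. Compound 4 is expected to fall between those, closer to compound 2, at about 30 nM with a plausible range of 5 nM to 200 nM. This corresponds to an expected step of a 10-fold higher number from compound 2 to compound 4 (1.01 log units; beyond the scatter), upward and beyond the scatter.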

Compound 4, half-maximal inhibitory concentration: 13.8 nM
Beside the measured number, compound 4's estimate is 2.2-fold (0.34 log units) above it, within the range that was stated.
By their numbers in this assay, from the lowest: compound 2; then compound 4; then compounds 1 and 3 (each within the scatter of the next).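

Among the compounds shown here, the step is the first comparison in which only the group on this aromatic carbon changes, and it gives a size for that change: a 4.7-fold higher number from compound 2 to compound 4 (0.67 log units; beyond the scatter). The fused two-ring amine of compound 2, with its defined stereocentre, can give way to the single-ring 4-ethylpiperazin-1-yl group at a modest cost, and in this assay compound 4 still gives 13.8 nM. Nothing shown here accounts for the difference between these two groups.

The compounds shown leave open how a methyl, a propyl or a longer chain would compare with the ethyl group on this ring. They also leave open how the opposite stereocentre in the fused amine of compound 2 would read in this assay.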